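The source may hold more compounds than are shown below. What is called first, only, known or untested is meant among the compounds shown, and "the series" means these compounds.

Measured so far in a functional assay on Daudi cells (Homo sapiens) for antiproliferative activity; a lower number here means a stronger inhibitor, a higher number a weaker inhibitor:
compound 1 `Nc1ncnc2c1c(-c1ccc(Oc3ccccc3)cc1)cn2[C@H]1CCN(C[C@H]2CO2)C1`: 15700 nM
compound 2 `Nc1ncnc2c1c(-c1ccc(Oc3ccccc3)cc1)cn2C[C@H]1CCCN1C[C@@H]1CO1`: 7040 nM
compound 3 `CC(C)(C)c1ccc(COc2ccc(-c3cn([C@H]4CCN(C[C@@H]5CO5)C4)c4ncnc(N)c34)cc2)cc1`: 6970 nM

Compound 3 gives the lowest of the three numbers, but it sits within the scatter of compound 2 and is separated from compound 1 only by a modest gap. Within the data shown here, the one computed step among the measured compounds, a 2.2-fold lower number from compound 1 to compound 2 (0.35 log units; beyond the scatter), concerns the group on the aromatic nitrogen and not the aryl ether.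

Compound 4 `Nc1ncnc2c1c(-c1ccc(Oc3ccccc3)cc1)cn2[C@H]1CCN(C[C@@H]2CO2)C1` is not yet measured. From compound 3 it differs by phenyl in place of 4-(tert-butyl)benzyl on an oxygen on an aromatic ring. Among the measured compounds shown here, no measured step touches this position, so there is no direct precedent; what can be said is that compounds 1 and 2, which carry the phenoxy group, give numbers in the same broad range as compound 3. The change from compound 3 to compound 4 is therefore expected to bring no step beyond the scatter, or at most a small rise, a 1.4-fold higher number from compound 3 to compound 4 (0.16 log units; within the scatter). Compound 4 is estimated at 10000 nM, within 4000 nM to 25000 nM.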

Compound 4, half-maximal inhibitory concentration: 5480 nM
Compound 4: the middle estimate sits 1.8-fold (0.26 log units) above what was measured, within the range that was stated.
By their numbers in this assay, from the lowest: compounds 4, 3 and 2 (each within the scatter of the next); then compound 1.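

In this assay, among these compounds, the first comparison of configuration alone gives a 2.9-fold lower number from compound 1 to compound 4 (0.46 log units; beyond the scatter), so the drawn configuration at a saturated ring carbon carries a gap beyond the scatter, and the step is traced to that configuration: the fact that compounds 1 and 4 differ only in the configuration as drawn. On the oxygen on an aromatic ring, 4-(tert-butyl)benzyl and phenyl are not separated, with a 1.3-fold lower number from compound 3 to compound 4 (0.10 log units; within the scatter), so the larger group costs nothing readable here. On the aromatic nitrogen, a 1.3-fold lower number from compound 2 to compound 4 (0.11 log units; within the scatter), so the difference seen earlier with a 2.2-fold lower number from compound 1 to compound 2 (0.35 log units; beyond the scatter) does not hold for the other configuration.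

Every compound shown carries the (oxiran-2-yl)methyl group, so its own part in these numbers stays open, and an acrylamide in its place would test it. Also open, going by these compounds, is whether configuration matters equally with 4-(tert-butyl)benzyl on the oxygen.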